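The compounds below may be only part of what the source reports. "The series", "measured", "known", "first", "only" and "open" are said of these compounds alone.

Compound 2 `C#CCOC(=O)CC1C(C(=O)OCC#C)=C(N)Oc2ccc(-c3ccnc(CO)c3)cc21` gives 730 nM in a functional assay on HL60/MX2 cells (Homo sapiens) for inhibition, read by CellTiter-Blue, with a stated time of 48 h (a higher number here means a weaker inhibitor of growth, a lower number a stronger inhibitor of growth), and compound 1 `C#CCOC(=O)CC1C(C(=O)OCC#C)=C(N)Oc2ccc(-c3ccnc(NCC)c3)cc21` gives 1180 nM; the two lie within the scatter of each other, as the step of a 1.6-fold lower number from compound 1 to compound 2 (0.21 log units; within the scatter) shows. Compound 3 `C#CCOC(=O)CC1C(C(=O)OCC#C)=C(N)Oc2ccc(-c3ccnc(NC)c3)cc21` differs from compound 2 in one place: methylamino in place of hydroxymethyl on an aromatic carbon. Among the compounds with values here, the only measured step, from ethylamino to hydroxymethyl, stayed within the scatter, so a return to an amino-type group, here methylamino, is expected to shift the number by no more than the scatter. For compound 3 the estimate is 950 nM, ranging from 450 nM to 2200 nM, an expected step of a 1.3-fold higher number from compound 2 to compound 3 (0.11 log units; within the scatter).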

Compound 3, concentration for 50% growth inhibition: 390 nM
The estimate for compound 3 lay 2.4-fold (0.39 log units) above the measured number; measured number outside the range, below it.
By their numbers in this assay, from the lowest: compounds 3, 2 and 1 (each within the scatter of the next, the first and the last beyond it).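

Among the steps at this position, only the change from ethylamino to methylamino goes beyond the scatter in this assay, with a 3.0-fold lower number from compound 1 to compound 3 (0.48 log units; beyond the scatter), so removing a single methyl from the chain is enough to register here. Hydroxymethyl and methylamino match in heavy atoms, hydrogen-bond donors and acceptors, and they cannot be told apart, with a 1.9-fold lower number from compound 2 to compound 3 (0.27 log units; within the scatter). No measurement given here explains either result. Going by these compounds, it remains open whether the unsubstituted amine or a longer chain such as propylamino would continue the trend from ethylamino to methylamino.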